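Sulfonyl variants on the shared core

This account rests on a few compounds, and the source may have more. Where it says the series, first, only, none or still open, it means among the compounds named here.

Compound 1 `C=CCNC(=O)n1c(-c2ccc(OC)cc2)cc(=O)c2c(OC)cc(OC)cc21` carries an allylcarbamoyl group on the aromatic nitrogen of the shared core; compound 2 `COc1ccc(-c2cc(=O)c3c(OC)cc(OC)cc3n2S(=O)(=O)c2ccc(F)cc2)cc1` and compound 3 `COc1ccc(-c2cc(=O)c3c(OC)cc(OC)cc3n2S(=O)(=O)c2cccc(Br)c2)cc1` carry a (4-fluorophenyl)sulfonyl and a (3-bromophenyl)sulfonyl group there. In a functional assay on HepG2 cells (Homo sapiens) for antiproliferative activity, with a stated time of 72 h (a higher number here means that more compound is needed for the effect, a lower number that less compound is needed), compound 1 reaches only the limit > 20000 nM. Compound 2 likewise gives only the limit > 65500 nM. Compound 3 also stops at the limit > 58600 nM, so every value shown is a limit and no order among the three can be read. Compound 4 `COc1ccc(-c2cc(=O)c3c(OC)cc(OC)cc3n2S(=O)(=O)Cc2ccccc2)cc1` differs from compound 3 by benzyl in place of 3-bromophenyl on a sulfonyl sulfur. For the measured compounds named here, the one measured change on the sulfonyl sulfur, a step that the two limits leave unreadable from compound 2 to compound 3, is unreadable, as are a step that the two limits leave unreadable from compound 1 to compound 2 and a step that the two limits leave unreadable from compound 1 to compound 3 (the limit of > 20000 nM in this assay, at which 1 of the 3 values shown sits, (the limit of > 58600 nM in this assay, at which 1 of the 3 values shown sits), (the limit of > 65500 nM in this assay, at which 1 of the 3 values shown sits)). The step that the limit leaves unreadable from compound 3 to compound 4 is therefore expected to stay unreadable. For compound 4 the estimate is 60000 nM, with a range from 20000 nM to 200000 nM.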

Compound 4, half-maximal effective concentration: > 34400 nM
Compound 4 gave a limit, no number (the forecaster's own chance of this, stated with the estimate: 85%); the middle value does not contradict the limit.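

Compound 4 stops at the limit > 34400 nM, so its steps to compound 1, compound 2 and compound 3 cannot be read. The compounds shown leave open whether any group on the shared core's aromatic nitrogen gives a measurable effect in this assay.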